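The compounds below may be only part of what the source reports. "The series", "measured", "known", "first", "only" and "open" are said of these compounds alone.

The shared core carries, at one aromatic carbon, a variable aryl group, and three compounds with that core have been run in an ADME assay on microsomes from liver (Homo sapiens) for metabolic stability, read by LC-MS, using NADPH, with stated times of 5 min and 30 min, tested at 1 uM; on this read-out higher numbers stand for fast clearance and lower numbers for slow clearance. Compound 1, `Cc1cc(-c2cnc(NCc3c(F)ccc4c3CCO4)c3cn[nH]c(=O)c23)n(C)n1`, gives 24 mL.min-1.g-1 in this assay. Compound 2, `O=C1c2ccccc2CN1c1cnc(NCc2c(F)ccc3c2CCO3)n2cnnc12`, gives 13 mL.min-1.g-1, and compound 3, `CN(C)Cc1ccc(C(=O)Nc2cnc(NCc3c(F)ccc4c3CCO4)n3cnnc23)cc1`, gives 13 mL.min-1.g-1; both of those numbers lie within the usual scatter of the number for compound 1, so no ordering among the three can be claimed, and none of the pairs has a step that can be computed from single changes.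

Compound 4, `Cc1nc(CO)ccc1-c1cnc(NCc2c(F)ccc3c2CCO3)c2cn[nH]c(=O)c12`, is the next member. It differs from compound 1 in one place: 6-(hydroxymethyl)-2-methylpyridin-3-yl in place of 1,3-dimethyl-1H-pyrazol-5-yl on an aromatic carbon

Among the compounds with values here, no measured step here shows how that kind of exchange moves the intrinsic clearance in microsomes, so the expectation rests on compound 1 alone. The step from compound 1 to compound 4 is expected to be a 1.2-fold lower number from compound 1 to compound 4 (0.08 log units; within the scatter), that is, no change beyond the scatter in either direction. Compound 4 is accordingly estimated to give 20 mL.min-1.g-1 in this assay, within a range from 8 mL.min-1.g-1 to 50 mL.min-1.g-1.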

Compound 4, intrinsic clearance in microsomes: 11 mL.min-1.g-1
Beside the measured number, compound 4's estimate is 1.8-fold (0.26 log units) above it, within the range that was stated.
By their numbers in this assay, from the lowest: compounds 4, 2, 3 and 1 (each within the scatter of the next, the first and the last beyond it).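

Within the data shown here, this exchange on an aromatic carbon gives the first step in this assay that can be read from a single change, a 2.2-fold lower number from compound 1 to compound 4 (0.34 log units; beyond the scatter), so the group at this position can move the intrinsic clearance in microsomes beyond the scatter, though only modestly. The change replaces a five-membered aromatic ring with a six-membered one and also brings in a hydrogen-bond donor, so this single step cannot be divided among those differences. Nothing measured here bears on why the number is lower.

The compounds shown leave open whether the step follows the six-membered ring or the hydroxymethyl, a question that a 2-methylpyridin-3-yl group without the hydroxymethyl would address. They also leave open how an amine or a carboxylic acid in place of that hydroxymethyl would stand in this assay.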